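This account rests on a few compounds, and the source may have more. Where it says the series, first, only, none or still open, it means among the compounds named here.

Measured so far in a functional assay on AS49-RAW cells (Homo sapiens) for antiproliferative activity, read by sulforhodamine B assay, with a stated time of 48 h; a lower number here means a stronger inhibitor, a higher number a weaker inhibitor:
compound 1, `Cc1cc(NS(=O)(=O)c2ccc(N/C(S)=N\c3ccnc4cc(C(F)(F)F)ccc34)cc2)on1`, gives 60200 nM;
compound 2, `Cc1noc(NS(=O)(=O)c2ccc(N/C(S)=N\c3ccnc4cc(C(F)(F)F)ccc34)cc2)c1C`, gives 34000 nM;
compound 3, `O=S(=O)(Nc1ncccn1)c1ccc(N/C(S)=N\c2ccnc3cc(C(F)(F)F)ccc23)cc1`, gives 37800 nM.

Compound 4, `Cc1ccnc(NS(=O)(=O)c2ccc(N/C(S)=N\c3ccnc4cc(C(F)(F)F)ccc34)cc2)n1`, has not yet been measured in this assay.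

Compound 1 and compound 2 differ by methyl in place of hydrogen on an aromatic carbon, and the step is a 1.8-fold lower number from compound 1 to compound 2 (0.25 log units; within the scatter). Compound 3 and compound 4 differ by methyl in place of hydrogen on an aromatic carbon. This is the same kind of change, not the same: in compound 2 the methyl sits on a five-membered aromatic ring with one nitrogen and one oxygen, next to the ring atom that bears a large group and next to the ring atom that bears a methyl group; in compound 4 it sits on a six-membered aromatic ring with two nitrogens, next to the ring nitrogen, meta to a large group and opposite the ring nitrogen. The two cores differ by pyrimidin-2-yl in place of 3-methyl-1,2-oxazol-5-yl on a sulfonamide nitrogen, with a 1.6-fold lower number from compound 1 to compound 3 (0.20 log units; within the scatter); between compound 2 and compound 3 the step is a 1.1-fold higher number from compound 2 to compound 3 (0.05 log units; within the scatter).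

For compound 4 a step of a 1.4-fold lower number from compound 3 to compound 4 (0.13 log units; within the scatter) is expected, beside the earlier step of a 1.8-fold lower number from compound 1 to compound 2 (0.25 log units; within the scatter), which stayed within the scatter. Compound 4 is therefore expected to give 28000 nM. The expected range for compound 4 runs from 12000 nM to 70000 nM.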

Compound 4, half-maximal inhibitory concentration: 31000 nM
Beside the measured number, compound 4's estimate is 1.1-fold (0.04 log units) below it, within the range that was stated.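

In this assay, methyl in place of hydrogen on an aromatic carbon gives a 1.2-fold lower number from compound 3 to compound 4 (0.09 log units; within the scatter), and the change reads alike on the two cores: the same change on two cores in this assay, a 1.8-fold lower number (0.25 log units; within the scatter) from compound 1 to compound 2 and a 1.2-fold lower number (0.09 log units; within the scatter) from compound 3 to compound 4, 1.5-fold (0.16 log units) apart, within the scatter of two such steps. Neither step leaves the scatter, so what carries over from one core to the other is the lack of a readable effect, and the exchanges on the sulfonamide nitrogen that lead to compound 4 read the same way, with a 1.1-fold lower number from compound 2 to compound 4 (0.04 log units; within the scatter) and a 1.9-fold lower number from compound 1 to compound 4 (0.29 log units; within the scatter). Among these compounds, this does not show that methyl has no effect, since only two pairs are at hand, with the methyl on a five-membered aromatic ring in one and on a six-membered aromatic ring with two nitrogens in the other.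

The compounds shown leave open whether another group on that carbon, such as an amine, a methoxy group or a longer chain such as propyl, would give a step beyond the scatter. They also leave open how a carboxylic acid in place of the trifluoromethyl group on the shared core would read.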